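The source may report more compounds than this note shows. Statements on the series, on what has been measured and on what is new or still open speak of the compounds shown alone.

Values from a functional assay on Bel-7402 cells (Homo sapiens) for antiproliferative activity, read by MTT assay, with a stated time of 72 h (on this read-out lower numbers stand for stronger inhibition and higher numbers for weaker inhibition), are these:
Compound 1 (`C=C1C(=O)[C@@]23C(=O)OC[C@]4(C(=O)CCC(C)(C)[C@H]4C=O)[C@@H]2CC[C@@H]1[C@H]3O`) gives 4670 nM in this read-out
Compound 2 (`C=C1C(=O)[C@@]23C(=O)OC[C@]4([C@@H](OC(C)=O)CCC(C)(C)[C@H]4C=O)[C@@H]2CC[C@@H]1[C@H]3O`) gives > 50000 nM as a limit
Compound 3 (`C=C1C(=O)[C@@]23C(=O)OC[C@]4(C(=O)CCC(C)(C)[C@H]4C=O)[C@@H]2CC[C@@H]1[C@H]3OC(=O)CCC(=O)Oc1ccc(-c2cc(=S)ss2)cc1`) gives 1380 nM in this read-out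

Compound 2 has no measured number: it reads > 50000 nM in this assay and that reading is a limit of the assay, not a number. Among the compounds with values here, it is the only one of the three compounds at that edge (the limit of > 50000 nM in this assay, at which 1 of the 3 values shown sits).

Compound 4 (`C=C1C(=O)[C@@]23C(=O)OC[C@]4([C@@H](OC(C)=O)CCC(C)(C)[C@H]4C=O)[C@@H]2CC[C@@H]1[C@H]3OC(=O)CCCCC1CCSS1`) differs from compound 2 in one place (a group of 11 heavy atoms (8 carbon, 1 oxygen, 2 sulfur; one five-membered non-aromatic ring with 2 hetero atoms) in place of a hydrogen atom, on an oxygen on a saturated carbon), where a hydrogen atom on an oxygen on a saturated carbon gives way to the new group with its five-membered non-aromatic ring. Within the data shown here, no measured pair shows directly what such a change does. The nearest hint is in two values: compound 3 gives 1380 nM while compound 1 gives 4670 nM, and the lower number stands with compound 3. On that thin ground, the expected step runs toward stronger inhibition and is modest (an at least 2.5-fold lower number from compound 2 to compound 4 (0.39 log units; beyond the scatter)), and the reading may well stay at the limit. In this assay the estimate for compound 4 is 20000 nM with 6000 nM and 50000 nM as the expected ends of its range.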

Compound 4, half-maximal inhibitory concentration: 4580 nM
Beside the measured number, compound 4's estimate is 4.4-fold (0.64 log units) above it; the measured number lies below the stated range.
By their numbers in this assay, from the lowest: compound 3; then compounds 4 and 1 (each within the scatter of the next). At a limit, above all of these: compound 2.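

In this assay, the oxygen on a saturated carbon turns out to be a place where a large change can be made with a clear gain. Setting the group of 11 heavy atoms, with its five-membered non-aromatic ring with 2 hetero atoms, in place of the hydrogen atom gives an at least 10-fold lower number from compound 2 to compound 4 (1.03 log units; beyond the scatter), so a compound with no measurable reading now gives a real number. The earlier compounds offered only an indirect hint on a core carrying a carbonyl, whereas this step is seen directly on the core with the acetate ester, and it is a bound rather than a full size since compound 2 stands at a limit: the limit of > 50000 nM in this assay, at which 1 of the 4 values shown sits.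

The compounds shown leave open whether the gain belongs to the ring itself or simply to an ester at this oxygen, which a plain hexanoyl ester without the ring, or a chain ending in an amine or a carboxylic acid, would help to separate. They also do not tell how the same group would behave on the core of compound 1.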